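The source may hold more compounds than are shown below. What is called first, only, known or untested is meant among the compounds shown, and "the series" means these compounds.

Two compounds of the series carry the shared core with a branched saturated side chain on the carbon bound to the amine nitrogen. Compound 1 `CC(C)C[C@@H](N)CN(C(=O)[C@@H]1C[C@H]1c1ccccc1)c1ccc(-c2ccccc2)cc1` gives 1.8 nM in a functional assay for agonist activity at G protein-coupled receptor 88 (Homo sapiens), read by HTRF and cAMP accumulation; on this read-out higher numbers stand for an effect only at larger amounts of compound and lower numbers for an effect already at smaller amounts. Compound 2 `CC[C@@H](C)[C@H](N)CN(C(=O)[C@@H]1C[C@H]1c1ccccc1)c1ccc(-c2ccccc2)cc1` gives 1.4 nM in this assay, the lowest of the two numbers shown, with compound 1 as its nearest neighbour; the step of a 1.3-fold lower number from compound 1 to compound 2 (0.11 log units; within the scatter) says nothing beyond the scatter. Compound 3 `N[C@@H](CC1CCCCC1)CN(C(=O)[C@@H]1C[C@H]1c1ccccc1)c1ccc(-c2ccccc2)cc1` is not yet measured. It differs from compound 2 by cyclohexylmethyl in place of sec-butyl on a saturated chain carbon bound to an amine nitrogen and a saturated chain carbon. Among the measured compounds shown here, the only measured step bearing on this position, a 1.3-fold lower number from compound 1 to compound 2 (0.11 log units; within the scatter), shows that exchanging one branched alkyl side chain for another left the number unchanged within the scatter, so for compound 3 no step beyond the scatter is expected in this assay, the expected step being a 1.4-fold higher number from compound 2 to compound 3 (0.15 log units; within the scatter). The estimate for compound 3 in this assay is 2 nM, with a range from 0.7 nM to 6 nM.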

Compound 3, half-maximal effective concentration: 1.7 nM
Compound 3: middle estimate off by 1.2-fold (0.07 log units), on the high side; measured number inside the range.
By their numbers in this assay, from the lowest: compounds 2, 3 and 1 (each within the scatter of the next).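

Carrying a ring on this carbon does not separate the series in this assay: with cyclohexylmethyl in place of sec-butyl, the result is a 1.2-fold higher number from compound 2 to compound 3 (0.08 log units; within the scatter), although the entering group brings one six-membered non-aromatic ring of carbon only and 7 heavy atoms against 4. The comparison with the other open-chain side chain gives the same reading, a 1.1-fold lower number from compound 1 to compound 3 (0.02 log units; within the scatter), so compounds 1, 2 and 3 stand within the scatter of one another, and the earlier pair, with branched open-chain groups alone, could not show this for a ring-bearing group. No measurement offered here gives a reason for this flat result.

Still open, from the compounds shown here alone, is whether a benzyl group, with its aromatic ring, would stay within the scatter at this carbon. The same holds for a much smaller methyl group or a side chain ending in a carboxylic acid or a hydroxyl.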